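Urea versus amide linker in a pyrazole series

This account rests on a few compounds, and the source may have more. Where it says the series, first, only, none or still open, it means among the compounds named here.

Measured compounds:
- compound 1, `COc1cc(-c2nn(-c3cccc(NC(=O)Nc4cc(C(F)(F)F)cc(C(F)(F)F)c4)c3)cc2-c2ccncc2)ccc1Cl`, 623 nM
- compound 2, `COc1cc(-c2nn(-c3cccc(NC(=O)c4cccc(C(F)(F)F)c4)c3)cc2-c2ccncc2)ccc1Cl`, 1050 nM
- compound 3, `O=C(Nc1cccc(-n2cc(-c3ccncc3)c(-c3ccc(Cl)c(O)c3)n2)c1)Nc1ccc(Cl)c(Cl)c1`, 1190 nM

All three numbers come from a functional assay on NCI-H522 cells (Homo sapiens) for inhibition, read by sulforhodamine B assay, with a stated time of 48 h; on this read-out lower numbers stand for stronger inhibition of growth and higher numbers for weaker inhibition of growth. Compound 2, the amide of the set, gives 1050 nM in this assay; compound 3 is its nearest neighbour and compound 1 its furthest, and both gaps lie within the scatter, so no ranking among the three is supported.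

Compound 4, `COc1cc(-c2nn(-c3cccc(NC(=O)Nc4cccc(C(F)(F)F)c4)c3)cc2-c2ccncc2)ccc1Cl`, differs from compound 2 in one place: (3-(trifluoromethyl)phenyl)amino in place of 3-(trifluoromethyl)phenyl on a carbonyl carbon. Among the measured compounds shown here, this returns the linker to the urea type present in compound 1 and compound 3, while keeping the single trifluoromethyl-bearing ring of compound 2.

For the measured compounds named here, no step between measured compounds matches this change. Compound 1, which carries a urea of this kind with two trifluoromethyl groups, gives 623 nM, and compound 2 with the amide gives 1050 nM; these two numbers sit within the scatter of each other, so the urea-for-amide exchange is expected to produce at most a small step, if any, in this assay.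

The expected step from compound 2 to compound 4 is a 1.2-fold lower number from compound 2 to compound 4 (0.09 log units; within the scatter). Compound 4 is estimated at 850 nM, with a range of 300 nM to 2500 nM.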

Compound 4, concentration for 50% growth inhibition: 714 nM
Compound 4: middle estimate off by 1.2-fold (0.08 log units), on the high side; measured number inside the range.
By their numbers in this assay, from the lowest: compounds 1, 4, 2 and 3 (each within the scatter of the next).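

In this assay, the change from 3-(trifluoromethyl)phenyl to (3-(trifluoromethyl)phenyl)amino on a carbonyl carbon can now be read directly, without a second difference in the aromatic ring, as a 1.5-fold lower number from compound 2 to compound 4 (0.17 log units; within the scatter); amide and urea linkers are therefore not separated by this single pair. Compound 4 also isolates the second trifluoromethyl of compound 1, and hydrogen in place of trifluoromethyl on an aromatic carbon, read as a 1.1-fold higher number from compound 1 to compound 4 (0.06 log units; within the scatter), likewise gives no resolved separation in this growth read-out. No measurement available on these compounds bears on the reason for either result.

The compounds shown leave open whether any replacement on this aromatic ring can move the number beyond the scatter, for example a carboxylic acid or a primary amine in place of trifluoromethyl. They also leave open whether the carbonyl carbon tolerates a longer chain in place of the aromatic ring, and whether the urea and amide linkers would separate in a pair carrying a different substituent pattern on that ring.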